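Shifting the Methyl on the Piperidine of Compound 3

The source may report more compounds than this note shows. Statements on the series, on what has been measured and on what is new or still open speak of the compounds shown alone.

Measured so far:
compound 1, `Nc1ccccc1NC(=O)c1ccc(CSC(=S)N2CCN(c3ccc(Cl)cc3)CC2)cc1`, 15%
compound 2, `Nc1ccccc1NC(=O)c1ccc(CSC(=S)N2CCc3cc([N+](=O)[O-])ccc32)cc1`, 26.8%
compound 3, `CC1CCCCN1C(=S)SCc1ccc(C(=O)Nc2ccccc2N)cc1`, 64.4%

In a functional assay on MGC-803 cells (Homo sapiens) for antiproliferative activity, read by CCK-8 assay, with a stated time of 72 h, tested at 2 uM (on this read-out higher numbers stand for a stronger effect at the one concentration tested and lower numbers for a weaker effect), compound 3 gives the highest of the three numbers; compound 2 comes nearest, its value beyond the scatter below, and compound 1 lies further below still. Compound 4, `CC1CCN(C(=S)SCc2ccc(C(=O)Nc3ccccc3N)cc2)CC1`, differs from compound 3 in a single group: 4-methylpiperidin-1-yl in place of 2-methylpiperidin-1-yl on a thiocarbonyl carbon. Among the measured compounds shown here, no measured pair shows a change of this kind, so the data give no step size for it. A small step is therefore expected, a number 8.4 percentage points lower from compound 3 to compound 4 (within the scatter), quite possibly none beyond the scatter, with the direction uncertain. Compound 4 is estimated at 56% in this assay, within a range from 35% to 75%.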

Compound 4, a percentage reported as inhibition, at one concentration (the size of the read-out at that concentration, not a potency): 28.1%
For compound 4 the middle estimate is 27.9 percentage points above the measured one; the measured number lies below the stated range.
By their numbers in this assay, from the lowest: compound 1; then compounds 2 and 4 (each within the scatter of the next); then compound 3.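

In this assay, among the compounds shown here, 4-methylpiperidin-1-yl in place of 2-methylpiperidin-1-yl on a thiocarbonyl carbon gives a number 36.3 percentage points lower from compound 3 to compound 4 (beyond the scatter), the first step here between compounds that differ in one place. The two groups have the same atoms, so the read-out at this position depends on where the methyl sits, not just on which atoms are present. Nothing available explains the drop.

The compounds shown leave open how an unsubstituted piperidin-1-yl would compare with either methylated group. They also leave open whether an ethyl group in place of the methyl would keep the value of compound 3.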